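The compounds below may be only part of what the source reports. "The series", "measured", "known", "first", "only" and "open" are said of these compounds alone.

Measured so far:
compound 1 `COC(=O)c1nc(-c2ccc[nH]2)n(-c2ccc(F)cc2)n1` — 9580 nM
compound 2 `COC(=O)c1nc(-c2ccsc2)n(-c2ccc(C(F)(F)F)cc2)n1` — 34900 nM

Both compounds were run in a functional assay on NPC-TW01 cells (Homo sapiens) for inhibition, read by MTT assay, with a stated time of 72 h; a higher number here means a weaker inhibitor of growth, a lower number a stronger inhibitor of growth. Compound 2 stands highest of the two numbers; its nearest neighbour is compound 1, whose value lies beyond the usual scatter below it. Among the measured compounds shown here, the two differ in more than one place, so no single-change step between them can be drawn; their values alone show that compound 1 gives the lower number and compound 2 the higher.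

The next compound, compound 3 `COC(=O)c1nc(-c2ccc[nH]2)n(-c2ccc(C(F)(F)F)cc2)n1`, keeps the trifluoromethyl-bearing ring of compound 2 and changes only the group on the shared core: 1H-pyrrol-2-yl in place of thiophen-3-yl on an aromatic carbon. For the measured compounds named here, the same pyrrolyl group is present in compound 1, which in this assay gives 9580 nM, while compound 2 gives 34900 nM; this is the only guide available, and it points toward a lower number for compound 3 than for compound 2, though the size is uncertain.

Compound 3 is therefore expected to land at 16000 nM, within the range 5000 nM to 45000 nM, an estimated step of a 2.2-fold lower number from compound 2 to compound 3 (0.34 log units; beyond the scatter).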

Compound 3, concentration for 50% growth inhibition: > 100000 nM
Compound 3 was reported as a limit (the forecaster's own chance of this, stated with the estimate: 10%); at least 6.2-fold (0.79 log units) between middle value and limit.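

Compound 3 is reported in this assay only as a limit, not as a number: the limit of > 100000 nM in this assay, at which 1 of the 3 values shown sits.

On the aromatic carbon between two ring nitrogen atoms, with the trifluoromethyl-bearing ring held constant, 1H-pyrrol-2-yl in place of thiophen-3-yl gives an at least 2.8-fold higher number from compound 2 to compound 3 (0.45 log units; beyond the scatter), so the pyrrolyl group does not bring a lower number with it in this setting. With 1H-pyrrol-2-yl held constant, trifluoromethyl in place of fluoro on the other ring gives an at least 10-fold higher number from compound 1 to compound 3 (1.01 log units; beyond the scatter), which shows that the number reached with this pyrrolyl group depends strongly on that second substituent, and both steps are minimum sizes set by the limit.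

The compounds shown leave open how thiophen-3-yl behaves alongside the fluoro-bearing ring, so whether the two changes act independently or together cannot yet be told. Also open, as far as these compounds go, is how the series responds to other groups on the shared core, such as a carboxylic acid or a primary amide in place of the methoxycarbonyl group, or a furan-2-yl ring in place of 1H-pyrrol-2-yl.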